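The source may hold more compounds than are shown below. What is called first, only, known or untested is meant among the compounds shown, and "the series" means these compounds.

Measured compounds:
Compound 1, `Cc1ccc(C#Cc2nc(C(N)=O)nn2COCCO)cc1`: in an ADME assay on Huh-5-2 cells (Homo sapiens) for cytotoxicity (on this read-out higher numbers stand for lower toxicity in this test and lower numbers for higher toxicity in this test), compound 1 gives > 50 ug/mL, which is a limit of the assay and not a number.
Compound 2, `CCCCCc1ccc(C#Cc2nc(C(N)=O)nn2COCCO)cc1`: in this assay compound 2 gives 25 ug/mL.

Going by the values given here, compound 2 holds the only number among the values shown; the one further value is a limit. Among the compounds with values here, the single measured step is an at least 2.0-fold lower number from compound 1 to compound 2 (0.30 log units; that floor lies within the scatter), which describes butyl in place of hydrogen on a saturated chain carbon bound to an aromatic carbon; its floor lies within the scatter, so the true size of that step is not fixed by the data, and compound 1 sits at the limit of > 50 ug/mL in this assay, at which 1 of the 2 values shown sits.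

Compound 3, `NC(=O)c1nc(C#Cc2ccc(F)cc2)n(COCCO)n1`, is still to be measured. It differs from compound 2 by fluoro in place of pentyl on an aromatic carbon. Within the data shown here, this change removes the five-carbon chain whose introduction, going from methyl in compound 1 to pentyl in compound 2, went with the only measured step. Fluoro is a single heavy atom, closer in size to the methyl of compound 1 than to the pentyl of compound 2. Compound 3 is therefore expected to move back toward the value of compound 1, with an estimated step of a 2.0-fold higher number from compound 2 to compound 3 (0.30 log units; within the scatter). Compound 3 is estimated at 50 ug/mL, with a range from 25 ug/mL to 100 ug/mL, and a fair chance that the assay again reports only a limit.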

Compound 3, half-maximal cytotoxic concentration: > 50 ug/mL
Compound 3: no number, only a limit; the forecaster's own chance of this, stated with the estimate: 60%; the middle value sits exactly at the limit.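

Fluoro in place of pentyl on an aromatic carbon gives an at least 2.0-fold higher number from compound 2 to compound 3 (0.30 log units; that floor lies within the scatter) in this assay, so a second change at this place is now on record, one that takes the chain away, and its true size again stays unfixed. Compound 3 gives a limit of the assay and not a number, and the step that would set it against the methyl of compound 1 cannot be read. With the methyl and fluoro compounds both at the limit, compound 2 alone carries a number, which ties the only number seen here to the pentyl chain, though no step beyond the scatter supports that link: the limit of > 50 ug/mL in this assay, at which 2 of the 3 values shown sit.

The compounds shown leave open what numbers lie behind the limits of compound 1 and compound 3, and so whether methyl and fluoro differ at all in this assay. They also leave open whether a shorter chain such as propyl, a longer chain such as octyl, an amine or a carboxylic acid on this aromatic carbon would give a number in this assay, and where that number would fall.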